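This account rests on a few compounds, and the source may have more. Where it says the series, first, only, none or still open, it means among the compounds named here.

Three compounds have been measured:

Compound 1, `COc1ccc2[nH]c(-c3ccccc3)c(C=C(C#N)C#N)c2c1`: in a functional assay on NCI-H322M cells (Homo sapiens) for inhibition, read by sulforhodamine B assay, with a stated time of 48 h (a lower number here means a stronger inhibitor of growth, a higher number a weaker inhibitor of growth), compound 1 gives 7400 nM.
Compound 2, `COc1ccc(-c2[nH]c3ccc(OC)cc3c2C=C(C#N)C#N)cc1`: in this assay compound 2 gives 380 nM.
Compound 3, `COc1ccc2[nH]c(-c3ccccc3)c(/C=C(\C#N)S(=O)(=O)c3ccccc3)c2c1`: in this assay compound 3 gives 30100 nM.

Compound 2 and compound 1 differ by a single change, (hydrogen in place of methoxy on an aromatic carbon), and that change produced a 19-fold higher number from compound 2 to compound 1 (1.29 log units; beyond the scatter). Compound 3 stands with the highest number of the three, and its nearest neighbour by value is compound 1; the difference between the core of compound 3 and the core of compound 2 is not broken down here, so only the two values themselves can be compared, and compound 3 lies far above compound 2.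

Compound 4, `N#C/C(=C\c1c(-c2ccccc2)[nH]c2ccccc12)S(=O)(=O)c1ccccc1`, has not yet been measured. It differs from compound 3 by hydrogen in place of methoxy on an aromatic carbon. Among the measured compounds shown here, this is the same kind of change as the one from compound 2 to compound 1, but not the same: in the earlier pair the position is para to a large group, whereas here it is meta to a fused ring and para to a fused ring, on a ring that is part of a fused system.

The expectation for compound 4 in this assay rests on the size and direction of a 19-fold higher number from compound 2 to compound 1 (1.29 log units; beyond the scatter), tempered by the different surroundings of the change and by compound 3 already standing at 30100 nM. A step of a 3.0-fold higher number from compound 3 to compound 4 (0.48 log units; beyond the scatter) is expected, smaller than the earlier one. Compound 4 is therefore estimated to give 90000 nM, most likely between 25000 nM and 300000 nM.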

Compound 4, concentration for 50% growth inhibition: 9200 nM
Estimate against measurement, compound 4: 9.8-fold (0.99 log units) above; measured number outside the range, below it.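

In this assay, replacing methoxy with hydrogen on an aromatic carbon of the fused two-ring system gave a 3.3-fold lower number from compound 3 to compound 4 (0.51 log units; beyond the scatter), so compound 4 inhibits growth more strongly than compound 3, whereas the same kind of change had weakened inhibition on the other core. Set side by side, the two steps run in opposite directions and the gap between them is larger than chance scatter would explain, which shows that the effect of this change did not carry from one core to the other: the same change on two cores in this assay, a 19-fold higher number (1.29 log units; beyond the scatter) from compound 2 to compound 1 and a 3.3-fold lower number (0.51 log units; beyond the scatter) from compound 3 to compound 4, 64-fold (1.80 log units) apart, beyond the scatter of two such steps This does not show why the direction reversed, for the two pairs differ both in the rest of the core and in the ring that carries the methoxy, and two pairs alone cannot separate those differences or predict the step on any further core.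

On these data alone, it remains open whether the reversal follows the phenylsulfonyl group or the ring bearing the methoxy, a question that a comparison of the same ring place on both cores could settle. Also open, as far as these compounds go, is how this place on the fused ring responds to a group other than methoxy or hydrogen, such as a hydroxyl, an amine or a longer alkoxy chain.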